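Swapping an aryl ring for furan on a growth inhibitor

This account rests on a few compounds, and the source may have more. Where it says the series, first, only, none or still open, it means among the compounds named here.

This study follows a small set of compounds that share one core and are tested in a functional assay on COLO 205 cells (Homo sapiens) for inhibition, read by sulforhodamine B assay, with a stated time of 48 h, tested at 50 uM; a lower number here means less inhibition of growth, a higher number more inhibition of growth at the concentration tested. Going by the values given here, compound 1 `COc1ccccc1/C=C/C(=O)/C=C/c1ccc(OCc2cn(CCCOc3cc(=O)oc4ccccc34)nn2)c(OC)c1` gives 57% and stands highest of the three numbers known so far. Compound 2 `COc1ccc(/C=C/C(=O)/C=C/c2ccc(OCc3cn(CCCCCOc4cc(=O)oc5ccccc45)nn3)c(OC)c2)cc1` gives 30%, and compound 3 `COc1cc(/C=C/C(=O)/C=C/c2ccco2)ccc1OCc1cn(CCCCCOc2cc(=O)oc3ccccc23)nn1` gives 33%; both lie well below compound 1, beyond the usual scatter.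

Compound 4 `COc1cc(/C=C/C(=O)/C=C/c2ccco2)ccc1OCc1cn(CCCOc2cc(=O)oc3ccccc23)nn1` has not been measured yet. It is made from compound 1 by one change: furan-2-yl in place of 2-methoxyphenyl on a double-bonded chain carbon bound to a double-bonded chain carbon. The closest guide is the step between compound 2 and compound 3, which carries the related exchange of 4-methoxyphenyl for furan-2-yl at the same place, and there the number moved by a number 3 percentage points higher from compound 2 to compound 3 (within the scatter), a shift inside the scatter. That pair differs from compound 1 and compound 4 in a second part of the molecule, so the comparison is not exact, and it is a single observation.

On this basis the exchange is expected to leave the growth inhibition roughly where compound 1 sits, so compound 4 is estimated at 52%, with a range from 38% to 66%. This corresponds to an expected step of a number 5 percentage points lower from compound 1 to compound 4 (within the scatter), which would not exceed the scatter.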

Compound 4, percent growth inhibition at one concentration: 59%
Compound 4: the middle estimate sits 7 percentage points below what was measured; the range from low to high includes it.
By their numbers in this assay, from the lowest: compounds 2 and 3 (each within the scatter of the next); then compounds 1 and 4 (each within the scatter of the next).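

In this assay, replacing 2-methoxyphenyl with furan-2-yl on a double-bonded chain carbon bound to a double-bonded chain carbon gives a step (a number 2 percentage points higher from compound 1 to compound 4 (within the scatter)), even though the ring that enters has 5 heavy atoms and the ring that leaves has 8. The earlier pair showed a related exchange only in compounds with numbers near the bottom of this small set (a number 3 percentage points higher from compound 2 to compound 3 (within the scatter)), whereas this pair shows that furan-2-yl can also stand at this place in a compound with one of the two highest numbers, so both readable exchanges at this place stay within the scatter. No measurement available here bears on why this place accepts either ring.

The groups shown at this place are all aromatic rings, so what a saturated piperidine ring, an amine or a carboxylic acid would do there remains open. Each number also comes from a single tested concentration, which leaves open whether compound 1 and compound 4 would still match at lower concentrations.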